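Replacing the cyanophenyl group on a weak inhibitor

The source may hold more compounds than are shown below. What is called first, only, known or untested is meant among the compounds shown, and "the series" means these compounds.

In a functional assay on Jurkat cells (Homo sapiens) (a higher number here means a weaker inhibitor, a lower number a stronger inhibitor), compound 1 `CC(C)[C@H](NC(=O)COc1cccc2ccccc12)C(=O)N[C@@H](CC(=O)O)C(=O)COc1ccccc1` gives 14000 nM. Compound 2 `CC(C)[C@H](NC(=O)COc1cccc2ccccc12)C(=O)N[C@@H](CC(=O)O)C(=O)COc1ccc(C#N)cc1` gives > 100000 nM, which is a limit and not a number, so it stands at the limit of > 100000 nM in this assay, at which 1 of the 2 values shown sits. Compound 3 `CC(=O)Nc1cccc(OCC(=O)[C@H](CC(=O)O)NC(=O)[C@@H](NC(=O)COc2cccc3ccccc23)C(C)C)c1` has 3-acetamidophenyl in place of 4-cyanophenyl on an oxygen on a saturated carbon. Among the compounds with values here, the one measured step that bears on this is cyano in place of hydrogen on an aromatic carbon, an at least 7.1-fold higher number from compound 1 to compound 2 (0.85 log units; beyond the scatter). Going by these compounds, that cyano is gone in compound 3, although the new group is untested, so a move back towards a lower number is expected. The expected change is an at least 3.3-fold lower number from compound 2 to compound 3 (0.52 log units; beyond the scatter). For compound 3 the estimated value in this assay is 30000 nM, with a range of 8000 nM to 120000 nM.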

Compound 3, half-maximal inhibitory concentration: > 100000 nM
Compound 3: only a limit was reported; the forecaster's own chance of this, stated with the estimate: 30%; at least 3.3-fold (0.52 log units) between middle value and limit.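

In this assay, a second group on the phenoxy ring now costs activity, with acetamido in place of hydrogen giving an at least 7.1-fold higher number from compound 1 to compound 3 (0.85 log units; beyond the scatter). The loss is therefore not tied to the nitrile alone, although 3-acetamidophenyl and 4-cyanophenyl differ in more than one way. The step between the two substituted compounds cannot be read, since both values are limits: the limit of > 100000 nM in this assay, at which 2 of the 3 values shown sit.

Going by these compounds, it remains open whether any group on this ring can match or improve on compound 1 at 14000 nM. A fluorine, a methoxy or an amine could help to answer that.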